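The source may report more compounds than this note shows. Statements on the series, on what has been measured and on what is new or still open speak of the compounds shown alone.

Measured so far in a functional assay on MDA-MB-231 cells (Homo sapiens) for inhibition, read by MTT assay, with a stated time of 48 h; on this read-out lower numbers stand for stronger inhibition and higher numbers for weaker inhibition:
compound 1 `Cn1c(/C=C2\SC(=O)N(CC(=O)N3CCOCC3)C2=O)nc2ccccc21` gives > 50000 nM
compound 2 `CCn1c(/C=C2\SC(=O)N(CC(=O)N3CCc4cc(OC)c(OC)cc4C3)C2=O)nc2ccccc21` gives > 50000 nM
compound 3 `CC(C)n1c(/C=C2\SC(=O)N(CC(=O)N3CCCC3)C2=O)nc2ccccc21` gives > 50000 nM

Each of these readings is a limit of the assay, not a number. Compound 2 therefore has no exact place on the scale, and the set sits together at one point: the limit of > 50000 nM in this assay, at which 3 of the 3 values shown sit. Compound 4 `COc1cc2c(cc1OC)CN(C(=O)CN1C(=O)S/C(=C\c3nc4ccccc4n3C(C)C)C1=O)CC2` changes compound 2 in one place, turning ethyl into isopropyl: methyl in place of hydrogen on a saturated chain carbon bound to an aromatic nitrogen and a saturated chain carbon. Going by the values given here, no measured pair shows the size of this kind of change. Compound 3 already carries isopropyl, and its reading is the limit > 50000 nM in this assay. The estimate for a number no higher from compound 2 to compound 4 (the limit leaves the size open) is therefore no expected change beyond the scatter. For compound 4 the expected value is 50000 nM, with an estimated range from 20000 nM to 100000 nM.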

Compound 4, half-maximal inhibitory concentration: 30600 nM
Compound 4: middle estimate off by 1.6-fold (0.21 log units), on the high side, within the range that was stated.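

With isopropyl in place of ethyl, compound 4 is the first compound shown with a number rather than a limit in this assay, at 30600 nM. The step is an at least 1.6-fold lower number from compound 2 to compound 4 (0.21 log units; that floor lies within the scatter), and its true size stays open because compound 2 stands at a limit: the limit of > 50000 nM in this assay, at which 3 of the 4 values shown sit.

Compound 3 also carries isopropyl, yet its reading is a limit, > 50000 nM.

Going by these compounds, what remains open is how a longer chain, such as butyl, or a benzyl group would read at this position with the rest of compound 4 unchanged.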